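Adding a methyl to the side chain of a cathepsin S inhibitor

The source may hold more compounds than are shown below. What is called first, only, known or untested is meant among the compounds shown, and "the series" means these compounds.

Two closely related compounds have been measured in an assay for inhibition of cathepsin S (Homo sapiens); a higher number here means a weaker inhibitor, a lower number a stronger inhibitor. Compound 1, with the structure `CC(C)(C)C[C@H](NC(=O)N1CCOCC1)C(=O)N[C@H](C#N)COCc1ccccc1`, gives 8 nM in this assay. Compound 2, with the structure `Cc1ccccc1COC[C@@H](C#N)NC(=O)[C@H](CC(C)C)NC(=O)N1CCOCC1`, gives 19 nM in this assay, the higher of the two numbers and beyond the usual scatter from compound 1. Compound 1 and compound 2 differ in two places at once, so the two numbers alone do not tell which change matters.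

Compound 3, with the structure `Cc1ccccc1COC[C@@H](C#N)NC(=O)[C@H](CC(C)(C)C)NC(=O)N1CCOCC1`, has not yet been measured. It differs from compound 2 in one place: methyl in place of hydrogen on a saturated chain carbon bound to three saturated chain carbons. Cut one bond further out, the same change reads isobutyl to neopentyl, so compound 3 carries the same neopentyl side chain as compound 1 together with the ether found in compound 2.

For the step from compound 2 to compound 3 a moderate move toward a lower number is expected, of the size a 2.1-fold lower number from compound 2 to compound 3 (0.32 log units; beyond the scatter), guided by compound 1 at 8 nM. Compound 3 is estimated at 9 nM, with a likely range from 3 nM to 27 nM.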

Compound 3, half-maximal inhibitory concentration: 12 nM
Beside the measured number, compound 3's estimate is 1.3-fold (0.12 log units) below it; the measured number falls inside the stated range.
By their numbers in this assay, from the lowest: compounds 1, 3 and 2 (each within the scatter of the next, the first and the last beyond it).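

In this assay, the methyl on the saturated chain carbon, which turns isobutyl into neopentyl, gives a 1.6-fold lower number from compound 2 to compound 3 (0.20 log units; within the scatter) and so, taken alone, has no effect that can be told apart from ordinary repeat variation. Compound 3 also isolates the second difference that was tangled up in the first pair, and the methyl in place of hydrogen on an aromatic carbon gives a 1.5-fold higher number from compound 1 to compound 3 (0.18 log units; within the scatter) and likewise stays inside that variation, so each of the two places can now be read on its own and neither single change shows a clear effect here. No independent measurement is available that speaks to what lies behind these two steps.

The three compounds cover only hydrogen and methyl at each of these two places, so neither result can be called a trend for the position as a whole. On these data alone, whether a longer chain or a cyclohexylmethyl group on the saturated side, or a chlorine or a methoxy group on the aromatic carbon, would shift the number beyond the scatter remains open.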